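Tosylate on the trifluoromethylphenyl triazole: working notes

A few compounds are considered here, and "the series" means these few. Any claim that something is new, unique, unknown or untested is made for them only; others in the source may bear on it.

Compound 1, `C=C1C[C@]23C[C@@]1(O)CC[C@H]2c1ccc(OS(=O)(=O)c2ccc(C)cc2)c(C)c1[C@@H]3Cn1cc(-c2ccc(OC)cc2)nn1`: in a functional assay on MCF7 cells (Homo sapiens) for cytotoxicity, read by MTT assay, with a stated time of 4 days (on this read-out lower numbers stand for stronger inhibition and higher numbers for weaker inhibition), compound 1 reports > 20000 nM, a limit of the assay.
Compound 2, `C=C1C[C@]23C[C@@]1(O)CC[C@H]2c1ccc(O)c(C)c1[C@@H]3Cn1cc(-c2ccc(C(F)(F)F)cc2)nn1`: in this assay compound 2 gives 12400 nM.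
Compound 3, `C=C1C[C@]23C[C@@]1(O)CC[C@H]2c1ccc(O)c(C)c1[C@@H]3Cn1cc(-c2ccccc2)nn1`: in this assay compound 3 reports > 20000 nM, a limit of the assay.

Going by the values given here, compound 2 holds the only plain number in the set; the other two values are limits (the limit of > 20000 nM in this assay, at which 2 of the 3 values shown sit). Among the compounds with values here, the one measured step, an at least 1.6-fold higher number from compound 2 to compound 3 (0.20 log units; that floor lies within the scatter), concerns the trifluoromethyl and not the phenol. Compound 4, `C=C1C[C@]23C[C@@]1(O)CC[C@H]2c1ccc(OS(=O)(=O)c2ccc(C)cc2)c(C)c1[C@@H]3Cn1cc(-c2ccc(C(F)(F)F)cc2)nn1`, differs from compound 2 by (4-methylphenyl)sulfonyl in place of hydrogen on an oxygen on an aromatic ring. Within the data shown here, no measured step covers this change. Compound 1, which carries the same sulfonyl ester, sits at > 20000 nM, a limit. A weakening, or no change beyond the scatter, is therefore expected, estimated as a 2.0-fold higher number from compound 2 to compound 4 (0.30 log units; within the scatter). For compound 4 the expected value in this assay is 25000 nM, with a range from 8000 nM to 80000 nM.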

Compound 4, half-maximal inhibitory concentration: > 20000 nM
Compound 4 ended at the assay's limit; the forecaster's own chance of this, stated with the estimate: 60%; the middle value lies beyond the limit too.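

The change from hydroxy to ((4-methylphenyl)sulfonyl)oxy gives an at least 1.6-fold higher number from compound 2 to compound 4 (0.20 log units; that floor lies within the scatter), so the ester removes the one plain number in this assay without a shift shown beyond the scatter. Trifluoromethyl therefore does not yield a plain number once this ester is present, and the step from methoxy to trifluoromethyl cannot be read. The set now gathers at one ceiling: the limit of > 20000 nM in this assay, at which 3 of the 4 values shown sit.

Going by these compounds, the true size of the ester step stays open. So does whether a methyl ether, an acetate or a carbamate on this oxygen would give a plain number.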